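The source may hold more compounds than are shown below. What is called first, only, known or untested is meant among the compounds shown, and "the series" means these compounds.

Among the compounds with values here, in a functional assay on KB cells (Homo sapiens) for inhibition (a higher number here means a weaker inhibitor, a lower number a stronger inhibitor), compound 1 `CCOC(=O)c1cn([C@@H]2O[C@H](CO)[C@@H](O)[C@H]2O)c2nnnc(N)c12` gives 80000 nM, while compound 2 `N=C(NN)c1cn([C@@H]2O[C@H](CO)[C@@H](O)[C@H]2O)c2nnnc(N)c12` gives 3000 nM, the lower of the two numbers measured so far. Compound 3 `NC(=O)c1cn([C@@H]2O[C@H](CO)[C@@H](O)[C@H]2O)c2nnnc(N)c12` keeps the shared core of compound 2 and changes one group: a group of 3 heavy atoms (1 carbon, 1 nitrogen, 1 oxygen; no ring) in place of a group of 4 heavy atoms (1 carbon, 3 nitrogen; no ring), on an aromatic carbon. Within the data shown here, the carbamoyl group sits on an aromatic carbon of a five-membered aromatic ring with 1 nitrogen, the same carbon that changed in the only measured step, a 27-fold lower number from compound 1 to compound 2 (1.43 log units; beyond the scatter). That large step shows that the group on this carbon can shift the number strongly in this assay, but it does not test carbamoyl itself. The direction therefore remains uncertain, and only a modest move towards a lower number is expected, an estimated 1.5-fold lower number from compound 2 to compound 3 (0.18 log units; within the scatter). For compound 3, the estimated value is 2000 nM, with an expected range from 200 nM to 20000 nM.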

Compound 3, half-maximal inhibitory concentration: 80 nM
Compound 3: the middle estimate sits 25-fold (1.40 log units) above what was measured; the whole stated range lies above it.
By their numbers in this assay, from the lowest: compound 3; then compound 2; then compound 1.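

Moving to carbamoyl on this aromatic carbon in this assay gives a 38-fold lower number from compound 2 to compound 3 (1.57 log units; beyond the scatter) and makes compound 3 the lowest of the three, so the group left by compound 2 was not the best of those shown at this position. The ester-to-amide change, amino in place of ethoxy on a carbonyl carbon, gives a 1000-fold lower number from compound 1 to compound 3 (3.00 log units; beyond the scatter) while the shared core stays the same. The identity of the atom on this carbonyl carbon therefore matters greatly, and the primary amide stands well apart from both the ethyl ester and the group in compound 2.

Nothing available here gives a measured reason for the size of these steps. On these data alone, whether a carboxylic acid, a nitrile or an N-methyl amide on this carbon would retain such a low number remains open.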